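Trimming a Methoxy Group from Compound 2

The source may hold more compounds than are shown below. What is called first, only, known or untested is meant among the compounds shown, and "the series" means these compounds.

Compound 1 `COc1cc(-c2cc(/C=C/C(=O)c3ccc(Cl)c(Cl)c3)[nH]n2)cc(OC)c1OC`: > 100000 nM
Compound 2 `COc1ccc(C(=O)/C=C/c2cc(-c3cc(OC)c(OC)c(OC)c3)n[nH]2)cc1OC`: 5100 nM

Compound 1 has no number in a functional assay on TK-10 cells (Homo sapiens) for inhibition, read by sulforhodamine B assay, with a stated time of 48 h; a higher number here means that more compound is tolerated, a lower number that less compound is tolerated: its entry of > 100000 nM is a limit of the assay. For the measured compounds named here, compound 2 gives 5100 nM in this assay, and that is the only actual number among the two values shown, so compound 2 stands alone as the single measured point. Going by the values given here, the one measured step, an at least 19-fold lower number from compound 1 to compound 2 (1.29 log units; beyond the scatter), is known only as a move away from that limit (the limit of > 100000 nM in this assay, at which 1 of the 2 values shown sits).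

Compound 3 `COc1ccc(C(=O)/C=C/c2cc(-c3cc(OC)c(OC)c(OC)c3)n[nH]2)cc1` differs from compound 2 by hydrogen in place of methoxy on an aromatic carbon, so that 3,4-dimethoxyphenyl becomes 4-methoxyphenyl on the carbonyl carbon. Among the compounds with values here, the step from compound 1 to compound 2 swapped the whole group on that carbon, not a single methoxy, so no measured step bears directly on this change. For compound 3 the step of a 1.6-fold higher number from compound 2 to compound 3 (0.20 log units; within the scatter) is therefore expected to stay within the usual scatter, perhaps leaning to a slightly higher number. Compound 3 is estimated at 8000 nM, in a range from 2500 nM to 25000 nM.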

Compound 3, concentration lethal to 50% of the cells: > 100000 nM
Compound 3: only a limit was reported (the forecaster's own chance of this, stated with the estimate: 10%); at least 12-fold (1.09 log units) between middle value and limit.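

In this assay, hydrogen in place of methoxy gives an at least 19-fold higher number from compound 2 to compound 3 (1.29 log units; beyond the scatter), a large change from the loss of a single group. For the compounds shown here, the only earlier step exchanged the entire group on the carbonyl carbon, whereas this one shows that the number is sensitive to one methoxy alone, at this position ortho to a methoxy group: the 3,4-dimethoxyphenyl group gives a measured value, but 4-methoxyphenyl does not. Compound 3 is reported only as a limit, and the step between compound 1 and compound 3 cannot be read: the limit of > 100000 nM in this assay, at which 2 of the 3 values shown sit.

Going by these compounds, whether a hydroxyl group or a fluorine atom on this carbon would keep a number like that of compound 2 remains open. Also open, on these data alone, is what the remaining methoxy of the 4-methoxyphenyl group contributes, and how far compound 3 lies beyond its limit.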